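This account rests on a few compounds, and the source may have more. Where it says the series, first, only, none or still open, it means among the compounds named here.

Measured compounds:
compound 1 `COc1ccc(/C=C/C=C/C(=O)c2cc(Cl)ccc2O)cc1` — 153 nM
compound 2 `O=C(/C=C/C=C/c1ccccc1)c1cc(Cl)ccc1O` — 54.8 nM
compound 3 `O=C(/C=C/C=C/c1ccccc1)c1ccccc1O` — 106 nM

In an in vitro assay on cells for inhibition of Amine oxidase [flavin-containing] B (Homo sapiens), read by Amplex Red, with a stated time of 15 min (a higher number here means a weaker inhibitor, a lower number a stronger inhibitor), compound 2 gives the lowest number of the three, but its distance to compound 3 lies within the scatter, so the two cannot be set in order; only compound 1 sits clearly apart, with a 2.8-fold lower number from compound 1 to compound 2 (0.45 log units; beyond the scatter) when its methoxy is removed.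

Compound 4 `O=C(/C=C/C=C/c1ccc(Cl)cc1)c1cc(Cl)ccc1O` differs from compound 2 in one place: chloro in place of hydrogen on an aromatic carbon. The ring that receives the chloro is the ring that in compound 1 carries the methoxy. Among the measured compounds shown here, two measured steps bear on the change. Removing the methoxy from that ring gave a 2.8-fold lower number from compound 1 to compound 2 (0.45 log units; beyond the scatter), a modest gain. Removing the chloro from the other ring gave a 1.9-fold higher number from compound 2 to compound 3 (0.29 log units; within the scatter), which stays within the scatter. A chloro is not a methoxy, and the one chloro already examined made no clear difference, so the account expects compound 4 to land close to compound 2, with the step of a 1.4-fold higher number from compound 2 to compound 4 (0.14 log units; within the scatter) expected to lie within or only just beyond the scatter. Compound 4 is therefore estimated at 75 nM, with a range from 30 nM to 190 nM.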

Compound 4, half-maximal inhibitory concentration: 1460 nM
For compound 4 the middle estimate is 19-fold (1.29 log units) below the measured one; measured number outside the range, above it.
By their numbers in this assay, from the lowest: compounds 2, 3 and 1 (each within the scatter of the next, the first and the last beyond it); then compound 4.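

In this assay, the position para to a large group proves far from indifferent: going from phenyl to 4-chlorophenyl gives a 27-fold higher number from compound 2 to compound 4 (1.43 log units; beyond the scatter), whereas the earlier compounds had shown only a modest change at this place, with the removal of the methoxy giving a 2.8-fold lower number from compound 1 to compound 2 (0.45 log units; beyond the scatter). Chloro and methoxy are also not interchangeable here, since exchanging one for the other gives a 9.5-fold higher number from compound 1 to compound 4 (0.98 log units; beyond the scatter), so the hydrogen, methoxy and chloro forms of this position fall into a clear order, with the chloro giving the highest number. The same atom on the other aromatic ring gave no such penalty, as its removal there gives a 1.9-fold higher number from compound 2 to compound 3 (0.29 log units; within the scatter), which lies within the scatter, so the effect of a chloro in this series depends on which ring carries it.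

Nothing in the data shown accounts for the size of this step at this position. The compounds shown leave open how a fluoro, a methyl or a hydroxyl would read at the same position, and whether a chloro placed elsewhere on this ring would give a similar step.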